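Adding a Second Halogen to Compound 1

The source may report more compounds than this note shows. Statements on the series, on what has been measured and on what is new or still open speak of the compounds shown alone.

Compound 1: `Fc1ccc(Cn2nnc3c(Br)cccc32)cc1`, 15 nM
Compound 2: `Clc1ccc(Cn2nnc3c(Br)cccc32)cc1`, 17 nM
Compound 3: `Brc1ccc(Cn2nnc3c(Br)cccc32)cc1`, 14 nM

Three compounds share one core and differ only in the halogen that sits on the outer six-membered aromatic ring of carbon only. In a functional assay on cells for positive allosteric modulation of metabotropic glutamate receptor 2 (Homo sapiens), read by fluorescence and calcium flux, with a stated time of 30 min (on this read-out lower numbers stand for an effect already at smaller amounts and higher numbers for an effect only at larger amounts of compound), compound 1 gives 15 nM, compound 2 gives 17 nM and compound 3 gives 14 nM. Compound 1 stands second highest of the three numbers, but the steps to both neighbours are small: a 1.1-fold higher number from compound 1 to compound 2 (0.05 log units; within the scatter), a 1.1-fold lower number from compound 1 to compound 3 (0.03 log units; within the scatter). The third swap is of the same kind: a 1.2-fold lower number from compound 2 to compound 3 (0.08 log units; within the scatter). Taken together, exchanging one halogen for another at this position leaves the read-out essentially unchanged.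

Compound 4 is `Fc1ccc(Cn2nnc3c(Br)cccc32)c(Cl)c1`. The change from compound 1 is chloro in place of hydrogen on an aromatic carbon; the fluoro group of compound 1 is kept and a chloro group is added ortho to the large group and meta to the fluoro group. For the measured compounds named here, none of the measured steps adds a second halogen, so they bear on the new step only indirectly; all they show is that halogens on this ring are tolerated with no movement beyond the scatter. No direction can be drawn from them. The expected step is therefore small: no change at the digits printed from compound 1 to compound 4 (within the scatter). Compound 4 is estimated at 15 nM, with a range from 6 nM to 40 nM.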

Compound 4, half-maximal effective concentration: 190 nM
Compound 4: the middle estimate sits 13-fold (1.10 log units) below what was measured; measured number outside the range, above it.
By their numbers in this assay, from the lowest: compounds 3, 1 and 2 (each within the scatter of the next); then compound 4.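

The earlier compounds shown here showed only that one halogen can replace another at the place of the fluoro group with no movement beyond the scatter; they said nothing about the other carbons of this ring. In this assay, the new place, ortho to a large group and meta to a fluoro group, behaves differently: adding chloro in place of hydrogen gives a 13-fold higher number from compound 1 to compound 4 (1.10 log units; beyond the scatter), so a single added chlorine atom is enough to produce a large step, and the tolerance seen at the first place does not carry over to this one. Nothing among the data shown explains why this step is so large.

The compounds shown leave open whether a fluoro, methyl or methoxy group at this same place would give a step of similar size, or whether the step is particular to chloro. They also leave open whether chloro on another carbon of this ring would give a step of similar size, so the effect cannot yet be assigned to this place alone.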